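Ethylamino replaces oxolanylmethylamino in a melanocortin receptor series

The compounds below may be only part of what the source reports. "The series", "measured", "known", "first", "only" and "open" are said of these compounds alone.

Compound 1 `CCC(C)[C@H](N)c1cc(C(F)(F)F)ccc1N1CCN(C(=O)CCc2ccc(OC)c(OC)c2Cl)CC1`: in an assay on HEK293 cells for displacement of a labelled ligand from Melanocortin receptor 4 (Homo sapiens) (a lower number here means a stronger inhibitor, a higher number a weaker inhibitor), compound 1 gives 2500 nM.
Compound 2 `CCC(C)[C@H](NCC1CCCO1)c1cc(C(F)(F)F)ccc1N1CCN(C(=O)CCc2ccc(Cl)cc2Cl)CC1`: in this assay compound 2 gives 780 nM.

Of these two numbers compound 2 holds the lower one, and compound 1 stands beyond the scatter above it. Compound 3 `CCN[C@@H](CC(C)C)c1cc(C(F)(F)F)ccc1N1CCN(C(=O)CCc2ccc(Cl)cc2Cl)CC1` differs from compound 2 in one place: 1-(ethylamino)-3-methylbutyl in place of 2-methyl-1-(((oxolan-2-yl)methyl)amino)butyl on an aromatic carbon. No measured pair shows this change, so the direction of the step in this assay cannot be read from the shown values. The expected step from compound 2 to compound 3 is a 1.3-fold lower number from compound 2 to compound 3 (0.11 log units; within the scatter), small and within the scatter. Compound 3 is estimated at 600 nM, in a range from 150 nM to 2500 nM.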

Compound 3, inhibition constant: 170 nM
The estimate for compound 3 lay 3.5-fold (0.55 log units) above the measured number; measured number inside the range.
By their numbers in this assay, from the lowest: compound 3; then compound 2; then compound 1.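

In this assay, 1-(ethylamino)-3-methylbutyl in place of 2-methyl-1-(((oxolan-2-yl)methyl)amino)butyl on an aromatic carbon gives a 4.6-fold lower number from compound 2 to compound 3 (0.66 log units; beyond the scatter). This position therefore responds to change beyond the scatter, and a group with no ring and fewer heavy atoms is accepted here. Nothing at hand explains this step.

The amine substituent and the carbon chain change together, so the compounds shown do not say which of the two carries the step. On these data alone, how a propylamino group on the same 3-methylbutyl chain would compare remains open.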